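The source may hold more compounds than are shown below. What is called first, only, known or untested is meant among the compounds shown, and "the series" means these compounds.

Compound 1 `Cc1ccc(-c2c(C)noc2C)cc1S(=O)(=O)NC1CCCC1` gives 1590 nM
Compound 2 `CC(=O)NCc1onc(C)c1-c1ccc(C)c(S(=O)(=O)NC2CCCC2)c1` gives 4920 nM

In a functional assay on MT4 cells (Homo sapiens) for cytotoxicity, read by CellTiter-Glo, with a stated time of 5 days (a lower number here means that less compound is needed, a higher number that more compound is needed for the effect), compound 2 has 4920 nM as the higher of the two numbers. Compound 3 `Cc1ccc(-c2c(C)noc2CO)cc1S(=O)(=O)NC1CCCC1` differs from compound 2 by hydroxy in place of acetamido on a saturated chain carbon bound to an aromatic carbon in one place, with hydroxy in place of acetamido on a saturated chain carbon bound to an aromatic carbon. Among the compounds with values here, the only measured step that bears on this is a 3.1-fold higher number from compound 1 to compound 2 (0.49 log units; beyond the scatter) for acetamido in place of hydrogen on such a carbon. A modest move to a lower number is therefore expected in this assay when acetamido leaves. The estimated step is a 2.0-fold lower number from compound 2 to compound 3 (0.29 log units; within the scatter) in size. Compound 3 is estimated at 2500 nM with an expected range of 1000 nM to 6500 nM in this read-out.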

Compound 3, half-maximal effective concentration: 6820 nM
Beside the measured number, compound 3's estimate is 2.7-fold (0.44 log units) below it; the whole stated range lies below it.
By their numbers in this assay, from the lowest: compound 1; then compounds 2 and 3 (each within the scatter of the next).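

In this assay the exchange of acetamido for hydroxy on this carbon gives a 1.4-fold higher number from compound 2 to compound 3 (0.14 log units; within the scatter) and so the two groups cannot be told apart here. Hydroxy, with one heavy atom against four for acetamido, still gives a 4.3-fold higher number from compound 1 to compound 3 (0.63 log units; beyond the scatter) and so both groups shown on this carbon go with a higher number than hydrogen, whatever their size. Nothing shown gives a reason for this. From the compounds shown here alone, whether an amine, a carboxylic acid or a longer chain on this carbon would also give a higher number than hydrogen stays open.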